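Adding a 4-methylpiperazin-1-yl group to compound 1

The source may hold more compounds than are shown below. What is called first, only, known or untested is meant among the compounds shown, and "the series" means these compounds.

In an ADME assay on Vero cells (Chlorocebus sabaeus) for cytotoxicity, read by MTT assay (on this read-out lower numbers stand for stronger inhibition and higher numbers for weaker inhibition), compound 1 `CN(Cc1ccc(F)cc1)c1cc(C(=O)Nc2ccccc2)ncn1` gives 297000 nM. For the measured compounds named here, this is the only number available, as compound 2 `CN(Cc1ccccn1)c1cc(C(=O)Nc2ccccc2)ncn1` has the result "not determined" (no result reported), so compound 1 cannot yet be ranked against another compound.

Compound 3 `CN1CCN(c2cccc(NC(=O)c3cc(N(C)Cc4ccc(F)cc4)ncn3)c2)CC1` keeps the core of compound 1 and differs in one place: 4-methylpiperazin-1-yl in place of hydrogen on an aromatic carbon. A 4-methylpiperazin-1-yl stands in place of a hydrogen on an aromatic carbon of a six-membered aromatic ring of carbon only, meta to a large group.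

Going by the values given here, no pair of measured compounds offers a step to go by, so any expectation here is loose. A moderate step towards stronger inhibition in this assay, beyond the scatter, is expected: a 4.2-fold lower number from compound 1 to compound 3 (0.63 log units; beyond the scatter). Compound 3 is estimated at 70000 nM, with an expected range from 18000 nM to 270000 nM.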

Compound 3, half-maximal inhibitory concentration: 118000 nM
Estimate against measurement, compound 3: 1.7-fold (0.23 log units) below; measured number inside the range.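

In this assay, placing a 4-methylpiperazin-1-yl on this aromatic carbon, meta to a large group, gives a 2.5-fold lower number from compound 1 to compound 3 (0.40 log units; beyond the scatter). This shows that the position is not indifferent to substitution: a hydrogen can give way to a large ring-bearing group, and the number moves modestly but beyond the usual scatter. Nothing available explains why the number moves.

With only one group at one place, the compounds shown leave open whether the step belongs to this particular group or would come with almost any substituent on this carbon. A morpholin-4-yl ring, a simple amine or a carboxylic acid at the same carbon would help to separate these possibilities, as would the 4-methylpiperazin-1-yl at another carbon of the ring.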